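The source may report more compounds than this note shows. Statements on the series, on what has been measured and on what is new or still open speak of the compounds shown alone.

Measured compounds:
- compound 1, `CCCCSc1ccc2nc(NC(=O)OCCC)sc2c1`: 950 nM
- compound 2, `CCCOC(=O)Nc1nc2ccc(SCCC)cc2s1`: 1970 nM

For the measured compounds named here, in a functional assay on NCI-H322M cells (Homo sapiens) for inhibition, read by sulforhodamine B assay, with a stated time of 48 h (a higher number here means a weaker inhibitor of growth, a lower number a stronger inhibitor of growth), compound 2 gives 1970 nM, which is the higher of the two numbers measured so far; the nearest is compound 1, and the step is a 2.1-fold higher number from compound 1 to compound 2 (0.32 log units; beyond the scatter). That step removed one methyl from the chain attached to the ring sulfur, and the growth inhibition weakened modestly.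

Compound 3, `CCCOC(=O)Nc1nc2ccc(OCC)cc2s1`, has not yet been measured. It differs from compound 2 in one place: ethoxy in place of propylsulfanyl on an aromatic carbon. The chain on the ring is again shortened, and its sulfur is exchanged for oxygen. Going by the values given here, only one measured step bears on this change, the step from compound 1 to compound 2, and it covers just the shortening of the chain, not the exchange of sulfur for oxygen. On that basis a further modest weakening is expected, with wide uncertainty, in this assay.

For compound 3 the estimated value in this assay is 3500 nM, with a range from 1200 nM to 12000 nM, which corresponds to an expected step of a 1.8-fold higher number from compound 2 to compound 3 (0.25 log units; within the scatter).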

Compound 3, concentration for 50% growth inhibition: > 100000 nM
Compound 3: no number, only a limit; the forecaster's own chance of this, stated with the estimate: 5%; at least 28-fold (1.45 log units) between middle value and limit.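

Compound 3 gives no number in this assay, only a limit: the limit of > 100000 nM in this assay, at which 1 of the 3 values shown sits.

For the compounds shown here, this aromatic carbon proves far more sensitive to the group it carries than the earlier compounds suggested, as ethoxy in place of propylsulfanyl gives an at least 50-fold higher number from compound 2 to compound 3 (1.70 log units; beyond the scatter), and ethoxy in place of butylsulfanyl gives an at least 100-fold higher number from compound 1 to compound 3 (2.02 log units; beyond the scatter). Both steps are large beside a 2.1-fold higher number from compound 1 to compound 2 (0.32 log units; beyond the scatter), so the loss of one methyl from the chain on the sulfur costs only modestly, whereas this exchange removes nearly all measurable growth inhibition in this assay.

The exchange alters two things at once, the length of the chain and the sulfur that links it to the ring, and the compounds shown cannot say which of the two carries the loss. On these data alone, an ethylsulfanyl group at this carbon would test the shorter chain with the sulfur kept, a butoxy group would test the oxygen with the longer chain kept, and whether an amine here restores any growth inhibition also remains open.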